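The source may report more compounds than this note shows. Statements on the series, on what has been measured and on what is new or still open speak of the compounds shown alone.

Of the compounds shown here, three have so far been tested in an assay on isolated protein for binding affinity to leukotriene B4 receptor 1 (Homo sapiens), tested at 1 uM; on this read-out higher numbers stand for more inhibition at the one concentration tested (going by the name of the read-out) and lower numbers for less inhibition. Compound 1 `CCCc1cc(C(C)=O)c(O)cc1OCCCCC#N` gives 37%, compound 2 `CCc1cc(C(C)=O)c(O)cc1OCCCC(C)(C)C#N` gives 46%, and compound 3 `CCc1cc(C(C)=O)c(O)cc1OCCCC(C)(C)C(=O)O` gives 43%. Compound 3 differs from compound 2 by a single change, (carboxy in place of cyano on a saturated chain carbon bound to three saturated chain carbons), and that change made a step of a number 3 percentage points lower from compound 2 to compound 3 (within the scatter). How the core of compound 1 differs from the core of compound 2 is not broken down here. Compound 4 `CCCc1cc(C(C)=O)c(O)cc1OCCCCC(=O)O` carries the same kind of change applied to compound 1: carboxy in place of cyano on a saturated chain carbon, four bonds along the chain from an oxygen on an aromatic ring. The surroundings differ: in compound 3 the carboxy sits on a saturated chain carbon bound to three saturated chain carbons, whereas in compound 4 it sits on a saturated chain carbon, four bonds along the chain from an oxygen on an aromatic ring. Since a number 3 percentage points lower from compound 2 to compound 3 (within the scatter) lay within the scatter, the step expected for compound 4 is a number 2 percentage points lower from compound 1 to compound 4 (within the scatter). Compound 4 is accordingly estimated at 35%, most likely between 22% and 48%.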

Compound 4, a percentage reported as inhibition, at one concentration (the size of the read-out at that concentration, not a potency): 0%
Estimate against measurement, compound 4: 35 percentage points above, and the stated range ends above it.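

Carboxy in place of cyano brings a number 37 percentage points lower from compound 1 to compound 4 (beyond the scatter) in this assay. The size of this change therefore does not carry reliably from one core to another in this series: the same change on two cores in this assay, a number 3 percentage points lower (within the scatter) from compound 2 to compound 3 and a number 37 percentage points lower (beyond the scatter) from compound 1 to compound 4, 34 percentage points apart, beyond the scatter of two such steps. The two pairs differ from each other in more than one place, so these results do not show which of those differences sets the gap, and two pairs cannot give a general rule.

The compounds shown leave open how an amide or a methyl ester in place of cyano on the same saturated chain carbon would read in this assay. They also leave open whether a carboxylic acid on a longer chain would behave like compound 4 or like compound 3.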